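This account rests on a few compounds, and the source may have more. Where it says the series, first, only, none or still open, it means among the compounds named here.

Compound 1 `Oc1cccc(-c2cc(-c3cccc(F)c3)cc(-c3cccc(O)c3)n2)c1` is examined in a functional assay on T47D cells (Homo sapiens) for inhibition (a lower number here means a stronger inhibitor, a higher number a weaker inhibitor), and gives 21300 nM. Among the numbers shown this is the highest of two, and the nearest neighbour is compound 2 `Oc1ccc(-c2cc(-c3cccc(F)c3)cc(-c3cccc(O)c3)n2)cc1`, which in this assay gives 3510 nM. For the measured compounds named here, the only measured step with a single change is a 6.1-fold lower number from compound 1 to compound 2 (0.78 log units; beyond the scatter), a shift of the hydroxyl on one of the phenyl rings. Compound 3 `Oc1ccc(-c2cc(-c3ccc(C(F)(F)F)cc3)cc(-c3ccccc3O)n2)cc1` carries a 4-(trifluoromethyl)phenyl group and in this assay reaches only > 50000 nM; that is a limit of the assay and not a number (the limit of > 50000 nM in this assay, at which 1 of the 3 values shown sits). Compound 4 `Oc1cccc(-c2cc(-c3ccc(C(F)(F)F)cc3)cc(-c3cccc(O)c3)n2)c1` has not yet been measured in this assay. It differs from compound 1 by 4-(trifluoromethyl)phenyl in place of 3-fluorophenyl on an aromatic carbon. Going by the values given here, no measured step changes this same group, so the step from compound 1 has no direct precedent; the one measured step, a 6.1-fold lower number from compound 1 to compound 2 (0.78 log units; beyond the scatter), concerns a different change and bears on it only indirectly. Among the compounds with values here, what the two values show is that compound 1 already stands at a weak level and that the one compound bearing 4-(trifluoromethyl)phenyl sits at the limit. Compound 4 is therefore expected to come out weaker, with a step of about a 2.1-fold higher number from compound 1 to compound 4 (0.32 log units; beyond the scatter). For compound 4 the estimate in this assay is 45000 nM, expected between 15000 nM and 130000 nM.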

Compound 4, half-maximal inhibitory concentration: 2330 nM
Estimate against measurement, compound 4: 19-fold (1.29 log units) above; the whole stated range lies above it.
By their numbers in this assay, from the lowest: compounds 4 and 2 (each within the scatter of the next); then compound 1. At a limit, above all of these: compound 3.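

In this assay, the position opposite the ring nitrogen proves responsive to the group it carries, with 4-(trifluoromethyl)phenyl in place of 3-fluorophenyl giving a 9.1-fold lower number from compound 1 to compound 4 (0.96 log units; beyond the scatter). For the compounds shown here, this is the first measured change at this position, and it shows that the 4-(trifluoromethyl)phenyl group, with 10 heavy atoms against 7 in the group it replaces, is compatible with a stronger number on the core of compound 1. Compound 3, the only other compound with this group, differs from compound 4 in more than one place, so it gives no clean comparison, and its value is a limit and not a number: the limit of > 50000 nM in this assay, at which 1 of the 4 values shown sits.

The compounds shown leave open whether the stronger number follows from the trifluoromethyl group itself or from where it sits on the ring, and whether a plain phenyl, or an amine or a carboxylic acid in place of the trifluoromethyl, would hold it. They also leave open whether this change would add to the step from moving the hydroxyl, a 6.1-fold lower number from compound 1 to compound 2 (0.78 log units; beyond the scatter), if the two were combined on one compound.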